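The source may report more compounds than this note shows. Statements on the series, on what has been measured and on what is new or still open speak of the compounds shown alone.

Measured so far:
compound 1 `Cc1noc(C)c1S(=O)(=O)N1CCC(N2CCC(C)CC2)CC1` — > 5000 nM
compound 2 `COc1cc(C)ccc1S(=O)(=O)N1CCC(N2CCC(C)CC2)CC1` — > 5000 nM

Compound 1 `Cc1noc(C)c1S(=O)(=O)N1CCC(N2CCC(C)CC2)CC1` was tested in a functional assay on DLD-1 cells (Homo sapiens) for antiproliferative activity, read by CellTiter-Glo, with a stated time of 72 h; a lower number here means a stronger inhibitor, a higher number a weaker inhibitor. In this assay compound 1 gives > 5000 nM, which is a limit of the assay rather than a number. Compound 2 `COc1cc(C)ccc1S(=O)(=O)N1CCC(N2CCC(C)CC2)CC1` gives > 5000 nM in this assay, again a limit. Compound 1 therefore stands at the limit of > 5000 nM in this assay, at which 2 of the 2 values shown sit, and nothing shown separates it from compound 2 in either direction.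

Compound 3 `CC1CCN(C2CCN(S(=O)(=O)c3ccc(Br)c(Cl)c3)CC2)CC1` has not yet been measured in this assay. It differs from compound 1 in one place: 4-bromo-3-chlorophenyl in place of 3,5-dimethyl-1,2-oxazol-4-yl on a sulfonyl sulfur. Going by the values given here, no measured pair shows this change, so its size cannot be read from the data.

The step of an at least 1.2-fold lower number from compound 1 to compound 3 (0.09 log units; that floor lies within the scatter) that the estimate below implies is expected to be small, not beyond the usual scatter, with a fair chance that this assay again reports only a limit. Compound 3 is expected at 4000 nM, with a range from 800 nM to 20000 nM.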

Compound 3, half-maximal inhibitory concentration: 12 nM
Compound 3: middle estimate off by 330-fold (2.52 log units), on the high side; the measured number lies below the stated range.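

The sulfonyl sulfur proves to be a place where the choice of group can separate inactive from strongly inhibiting compounds: in this assay, 4-bromo-3-chlorophenyl in place of 3,5-dimethyl-1,2-oxazol-4-yl gives an at least 410-fold lower number from compound 1 to compound 3 (2.61 log units; beyond the scatter). That size is only a floor, as the value for compound 1 is a limit of the assay and not a number. Having a six-membered aromatic ring of carbon only on the sulfonyl sulfur is not enough by itself, since compound 2 has such a ring, with methoxy and methyl groups on it, and remains at a limit, leaving compound 3 as the only compound shown with a measured number: the limit of > 5000 nM in this assay, at which 2 of the 3 values shown sit.

The compounds shown cannot tell whether the bromine, the chlorine or the two together account for the gain, as no ring carrying only one of these halogens appears among them. They also leave open how far the activity would hold with fluorine, a trifluoromethyl group or an amine on that ring.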